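Notes on the side-chain step from compound 3 to compound 4

A few compounds are considered here, and "the series" means these few. Any claim that something is new, unique, unknown or untested is made for them only; others in the source may bear on it.

Values in an ADME assay on MT2 cells (Homo sapiens) for cytotoxicity; a higher number here means that more compound is tolerated, a lower number that less compound is tolerated:
- Compound 1 `Cc1cc(C#N)cc(C)c1Oc1cc(Nc2ccc(C#N)cc2)c(N)cc1CO` gives 122000 nM
- Compound 2 `CNCc1cc(N)c(Nc2ccc(C#N)cc2)cc1Oc1c(C)cc(C#N)cc1C` gives 12700 nM
- Compound 3 `Cc1cc(C#N)cc(C)c1Oc1cc(Nc2ccc(C#N)cc2)c(N)cc1CNCCCO` gives 15100 nM

Compound 3 lies within the scatter of compound 2 and well short of compound 1. Next is compound 4 `COCc1cc(N)c(Nc2ccc(C#N)cc2)cc1Oc1c(C)cc(C#N)cc1C`, with methoxy in place of (3-hydroxypropyl)amino on a saturated chain carbon bound to an aromatic carbon. For the measured compounds named here, no measured compound carries methoxy. The closest evidence is an 8.1-fold lower number from compound 1 to compound 3 (0.91 log units; beyond the scatter) and a 9.6-fold lower number from compound 1 to compound 2 (0.98 log units; beyond the scatter), while a 1.2-fold higher number from compound 2 to compound 3 (0.08 log units; within the scatter). Compound 4 resembles compound 1 in lacking the amine, so a partial return is expected. The expected step is a 4.0-fold higher number from compound 3 to compound 4 (0.60 log units; beyond the scatter). For compound 4 the estimate is 60000 nM, with an expected range of 20000 nM to 150000 nM.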

Compound 4, half-maximal cytotoxic concentration: 146000 nM
Compound 4: the middle estimate sits 2.4-fold (0.39 log units) below what was measured, within the range that was stated.
By their numbers in this assay, from the lowest: compounds 2 and 3 (each within the scatter of the next); then compounds 1 and 4 (each within the scatter of the next).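

In this assay, methoxy in place of (3-hydroxypropyl)amino gives a 9.7-fold higher number from compound 3 to compound 4 (0.99 log units; beyond the scatter) and methoxy in place of methylamino gives an 11-fold higher number from compound 2 to compound 4 (1.06 log units; beyond the scatter) on the same saturated chain carbon bound to an aromatic carbon. Methyl in place of hydrogen on the oxygen gives a 1.2-fold higher number from compound 1 to compound 4 (0.08 log units; within the scatter) and so leaves hydroxy and methoxy indistinguishable here. Across these four compounds, none goes against a split between the two amines and the two oxygen-linked groups.

Nothing shown gives a reason for this split. On these data alone, whether a primary amine, a carboxylic acid or a longer ether chain at this place would fall with the amines or with the oxygen-linked groups remains open.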